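The source may report more compounds than this note shows. Statements on the series, on what has been measured and on what is new or still open speak of the compounds shown alone.

Measured so far:
compound 1, `CCOC(=O)CCCCCOc1ccc2c(=O)c(-c3ccc(O)cc3)coc2c1`: 5300 nM
compound 2, `O=C(O)CCCCCCCOc1ccc2c(=O)c(-c3ccc(O)cc3)coc2c1`: 6500 nM
compound 3, `O=c1c(-c2ccc(O)cc2)coc2cc(OCCCCCCO)ccc12`: > 9000 nM

All three share one core and differ only in the chain that hangs from an oxygen on one aromatic ring. In an assay (Cricetulus griseus) for inhibition of Monoamine oxidase (Homo sapiens) (a lower number here means a stronger inhibitor, a higher number a weaker inhibitor), compound 1 gives 5300 nM and compound 2 gives 6500 nM. On these data alone, compound 3 gives only a limit in this assay, > 9000 nM, so its true number is unknown beyond that edge (the limit of > 9000 nM in this assay, at which 1 of the 3 values shown sits). The steps among these three are small: a 1.2-fold higher number from compound 1 to compound 2 (0.09 log units; within the scatter); an at least 1.6-fold higher number from compound 1 to compound 3 (0.22 log units; that floor lies within the scatter); an at least 1.3-fold higher number from compound 2 to compound 3 (0.14 log units; that floor lies within the scatter).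

Compound 4, `O=C(O)COc1ccc2c(=O)c(-c3ccc(O)cc3)coc2c1`, is the next one to be measured. It differs from compound 3 in a single place: carboxy in place of 5-hydroxypentyl on a saturated chain carbon bound to an oxygen on an aromatic ring. Among the measured compounds shown here, no measured step shortens the chain in this way; the closest comparison is the change from hydroxy to carboxymethyl between compound 2 and compound 3, which moved the number by no more than the scatter. With only that to lean on, compound 4 is expected to stay in the weak range, at about 8000 nM with a plausible spread from 3000 nM to 30000 nM. The step this estimate implies is an at least 1.1-fold lower number from compound 3 to compound 4 (0.05 log units; that floor lies within the scatter), with a fair chance that the assay again reports only a limit.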

Compound 4, half-maximal inhibitory concentration: >> 9000 nM
Compound 4: no number, only a limit; the forecaster's own chance of this, stated with the estimate: 50%; middle value at least 1.1-fold (0.05 log units) from the limit.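

In this assay compound 4 gives only a limit, >> 9000 nM. This extends the series to its shortest chain, carboxymethoxy, and shows that keeping the carboxylic acid while cutting the chain back does not bring the number down: the readable steps are an at least 1.3-fold higher number from compound 2 to compound 4 (0.14 log units; that floor lies within the scatter) and an at least 1.6-fold higher number from compound 1 to compound 4 (0.22 log units; that floor lies within the scatter). On these data alone, each of these is only a floor, so the true distance from the two longer-chained compounds is unknown, and the step linking compound 3 and compound 4 cannot be read at all, since both values are limits.

The chains shown, whether they end in an ester, a carboxylic acid or an alcohol, therefore give no number that stands clearly apart from the others, and the true strength of compound 3 and compound 4 stays unknown. Still open, as far as these compounds go, is whether a different group at the end of the chain, such as an amine or an amide, would give a clearly lower number in this assay.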